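A few compounds are considered here, and "the series" means these few. Any claim that something is new, unique, unknown or untested is made for them only; others in the source may bear on it.

In an assay on cells with melanin-concentrating hormone receptor 1 (Homo sapiens) as the target, read by radioligand binding (a lower number here means a stronger inhibitor, a higher number a weaker inhibitor), the measured compounds stand as follows.
Compound 1, `CCC#CCOc1cccc2ccc(N)nc12`, gives only a limit of the assay, > 2000 nM.
Compound 2, `COC(C)(C)CCOc1cccc2ccc(N)nc12`, gives 132 nM.
Compound 3, `Nc1ccc2cccc(OCC3CCC3)c2n1`, gives 432 nM.

Compound 3 thus holds the higher of the two numbers in this assay; its nearest neighbour is compound 2, and the change a 3.3-fold higher number from compound 2 to compound 3 (0.51 log units; beyond the scatter) is beyond the scatter. Compound 1 sits at a limit, (the limit of > 2000 nM in this assay, at which 1 of the 3 values shown sits), so its step of an at least 4.6-fold lower number from compound 1 to compound 3 (0.66 log units; beyond the scatter) is known only as a lower bound.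

Compound 4, `COCCOCCOc1cccc2ccc(N)nc12`, differs from compound 3 in one place: (2-methoxyethoxy)methyl in place of cyclobutyl on a saturated chain carbon bound to an oxygen on an aromatic ring. For the measured compounds named here, the steps that bear on this site are an at least 4.6-fold lower number from compound 1 to compound 3 (0.66 log units; beyond the scatter) and a 3.3-fold higher number from compound 2 to compound 3 (0.51 log units; beyond the scatter). Compound 2, whose chain also carries an ether oxygen at this position, gave the lower number, so the entering (2-methoxyethoxy)methyl chain is expected to move compound 4 in the same direction as compound 2 rather than compound 1. Compound 4 is therefore expected to show a modest improvement, a 2.2-fold lower number from compound 3 to compound 4 (0.33 log units; beyond the scatter), with an estimated value of 200 nM (range 80 nM to 500 nM).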

Compound 4, half-maximal inhibitory concentration: > 2000 nM
Compound 4: no number, only a limit (the forecaster's own chance of this, stated with the estimate: 5%); middle value at least 10-fold (1.00 log units) from the limit.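

Compound 4 gives only a limit of the assay in this assay, > 2000 nM. An ether oxygen in the chain thus does not by itself bring the lower number seen with compound 2, as the large at least 15-fold higher number from compound 2 to compound 4 (1.18 log units; beyond the scatter) shows, and replacing cyclobutyl with (2-methoxyethoxy)methyl gives an at least 4.6-fold higher number from compound 3 to compound 4 (0.66 log units; beyond the scatter), so this site accepts some chains and not others. The step between compound 1 and compound 4 cannot be read, as both sit at the limit: the limit of > 2000 nM in this assay, at which 2 of the 4 values shown sit.

The compounds shown leave open whether the two methyl groups of compound 2 or the length of the chain in compound 4 decide the outcome. A shorter 2-methoxyethyl chain, or an amine at the chain end, would help to separate these readings.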